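From a Cyclobutyl to a Cyclohexyl Ring

A few compounds are considered here, and "the series" means these few. Any claim that something is new, unique, unknown or untested is made for them only; others in the source may bear on it.

Of the compounds shown here, two sharing one core have been measured in a functional assay on HT-29 cells (Homo sapiens) for inhibition, read by luminescence and CellTiter-Glo, with a stated time of 24 h; a lower number here means that less compound is needed, a higher number that more compound is needed for the effect. Compound 1 `CN1C(=S)[C@@H](NC(=O)c2nc(Cc3ccccc3)n(CCCCC#N)n2)COc2ccccc21` gives 2680 nM, and compound 2 `CN1C(=S)[C@@H](NC(=O)c2nc(Cc3ccccc3)n(C3CCC3)n2)COc2ccccc21` gives 181 nM, the lower of the two numbers. Compound 3 `CN1C(=S)[C@@H](NC(=O)c2nc(Cc3ccccc3)n(C3CCCCC3)n2)COc2ccccc21` keeps that core and changes one group: cyclohexyl in place of cyclobutyl on an aromatic nitrogen. For the measured compounds named here, only one measured step bears on this change: a 15-fold lower number from compound 1 to compound 2 (1.17 log units; beyond the scatter), with cyclobutyl in place of 4-cyanobutyl on the same aromatic nitrogen. That step was large, so this group can clearly move the number. However, it compares a ring with an open chain, not two rings of different size, so it gives no firm direction here. In this assay, no step beyond the scatter is expected, although a slightly higher number seems the better guess. The estimated step is a 1.7-fold higher number from compound 2 to compound 3 (0.22 log units; within the scatter). For compound 3 the expected value is 300 nM, with an estimated range from 90 nM to 1000 nM.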

Compound 3, half-maximal effective concentration: 4000 nM
Compound 3: the middle estimate sits 13-fold (1.12 log units) below what was measured, outside the stated range (above it).
By their numbers in this assay, from the lowest: compound 2; then compounds 1 and 3 (each within the scatter of the next).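

In this assay, the size of the ring on this aromatic nitrogen matters a great deal: cyclohexyl in place of cyclobutyl gives a 22-fold higher number from compound 2 to compound 3 (1.34 log units; beyond the scatter), so a ring of carbon at this place is not enough to keep the low number of compound 2. The open 4-cyanobutyl chain and the cyclohexyl ring cannot be told apart, with a 1.5-fold higher number from compound 1 to compound 3 (0.17 log units; within the scatter), and of these three groups only cyclobutyl stands apart. No measurement shown here explains why the larger ring raises the number so sharply.

The compounds shown leave open whether a cyclopentyl ring stays close to compound 2 or close to compound 3, and whether a cyclopropyl ring does as well as cyclobutyl. They also leave open how a short ethyl chain or a ring carrying an amine would behave at this place.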